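From pyridin-3-yl to phenyl in a weakly active series

This account rests on a few compounds, and the source may have more. Where it says the series, first, only, none or still open, it means among the compounds named here.

Among the compounds with values here, compound 1 `CCCSc1nc(N/N=C/c2cccnc2)c2nnn(Cc3ccccc3)c2n1` is one of two compounds measured in a functional assay on MCF7 cells (Homo sapiens) for antiproliferative activity, read by MTT assay, with a stated time of 72 h; on this read-out higher numbers stand for weaker inhibition and lower numbers for stronger inhibition. In this assay compound 1 gives 58700 nM, the only result recorded as a number. Compound 2 `CCCSc1nc(N/N=C(\C)c2ccccc2O)c2nnn(Cc3ccc(F)cc3)c2n1` is recorded at > 64000 nM, which is a limit of the assay rather than a number, matching (the limit of > 64000 nM in this assay, at which 1 of the 2 values shown sits). The unmeasured compound 3 `CCCSc1nc(N/N=C/c2ccccc2)c2nnn(Cc3ccccc3)c2n1` differs from compound 1 in a single place: phenyl in place of pyridin-3-yl on a carbon with a double bond to nitrogen. Within the data shown here, no step between measured compounds is available to gauge what such an exchange does. Because compound 1 already sits at 58700 nM, close to the upper edge of this assay, the step from compound 1 to compound 3 is expected to be small, a 1.0-fold higher number from compound 1 to compound 3 (0.01 log units; within the scatter), with no direction beyond the scatter. Compound 3 is therefore estimated at 60000 nM, within a range from 25000 nM to 130000 nM, with a real chance that only a limit is reported.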

Compound 3, half-maximal inhibitory concentration: > 64000 nM
Compound 3: only a limit was reported; the forecaster's own chance of this, stated with the estimate: 45%; at least 1.0-fold (0.02 log units) between middle value and limit.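

In this assay, phenyl in place of pyridin-3-yl on a carbon with a double bond to nitrogen gives an at least 1.0-fold higher number from compound 1 to compound 3 (0.03 log units; that floor lies within the scatter). Within the data shown here, this is the first step readable at this position, but it rests on a limit rather than a number for compound 3, and its floor does not separate the two compounds. The size of the change therefore cannot be fixed, because the result joins the others at the upper edge of the assay: the limit of > 64000 nM in this assay, at which 2 of the 3 values shown sit.

The compounds shown leave open whether the nitrogen of pyridin-3-yl contributes anything to the activity of compound 1. They also leave open what an amine or a carboxylic acid carried on the phenyl at this place would do in this assay.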